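A few compounds are considered here, and "the series" means these few. Any claim that something is new, unique, unknown or untested is made for them only; others in the source may bear on it.

Measured in a functional assay on CHO cells for agonist activity at adenosine receptor A2b (Homo sapiens), read by AlphaScreen and cAMP accumulation; on this read-out lower numbers stand for an effect already at smaller amounts and higher numbers for an effect only at larger amounts of compound:
Compound 1 `CNC(=O)CSc1nc(N)c(C#N)c(-c2ccc(OCC3CC3)cc2)c1C#N`: 94 nM
Compound 2 `N#Cc1c(N)nc(SCc2ncc[nH]2)c(C#N)c1-c1ccc(OCC2CC2)cc1`: 9.5 nM
Compound 3 `N#Cc1c(N)nc(SCc2cnc[nH]2)c(C#N)c1-c1ccc(OCC2CC2)cc1`: 139 nM

Among these three, compound 1 gives the second highest number. Its nearest neighbour is compound 3, as the difference a 1.5-fold higher number from compound 1 to compound 3 (0.17 log units; within the scatter) stays within the scatter. Compound 2 lies furthest away, with a 9.9-fold lower number from compound 1 to compound 2 (1.00 log units; beyond the scatter), and the gap a 15-fold higher number from compound 2 to compound 3 (1.17 log units; beyond the scatter) is large.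

Compound 4 `CCOc1ccc(-c2c(C#N)c(N)nc(SCC(=O)NC)c2C#N)cc1` keeps the shared core of compound 1 and alters only the ether chain: methyl in place of cyclopropyl on a saturated chain carbon bound to an oxygen on an aromatic ring.

None of the three measured steps touches this place. All of them exchange the group on the saturated chain carbon bound to a sulfur, and they run from a modest to a large size there, while the cyclopropylmethoxy part stays fixed in every measured compound. The data therefore give no direct guide for the ether side, and the expectation for compound 4 rests on the value of compound 1 alone, with a broad range. The step expected from this change in this assay is a 1.4-fold higher number from compound 1 to compound 4 (0.14 log units; within the scatter). Compound 4 is accordingly estimated at 130 nM, within a range from 35 nM to 500 nM.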

Compound 4, half-maximal effective concentration: 211 nM
Compound 4: the middle estimate sits 1.6-fold (0.21 log units) below what was measured; low and high end bracket the measured number.
By their numbers in this assay, from the lowest: compound 2; then compounds 1, 3 and 4 (each within the scatter of the next, the first and the last beyond it).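

In this assay the ether chain proves to be a place that responds: with methyl in place of cyclopropyl on a saturated chain carbon bound to an oxygen on an aromatic ring, there is a 2.2-fold higher number from compound 1 to compound 4 (0.35 log units; beyond the scatter). Going by these compounds alone, this modest step is the first change outside the group on the saturated chain carbon bound to a sulfur, and it shows that going from cyclopropylmethoxy to ethoxy, which removes the three-membered ring, moves the number beyond the scatter. Nothing available here accounts for this step.

The compounds shown leave open whether the same exchange would give a step of similar size with 1H-imidazol-2-yl on the saturated chain carbon bound to a sulfur, as in compound 2. They also leave open how a longer chain such as n-butyl, or an amine at the end of the ether chain, would read in this assay.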